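A few compounds are considered here, and "the series" means these few. Any claim that something is new, unique, unknown or untested is made for them only; others in the source may bear on it.

Compound 1 `CCOc1cccc(-c2ccc(C(=O)N(Cc3cccc(OCCCCCC(=O)O)c3)C(C)C)cc2)c1`: > 20800 nM, a limit
Compound 2 `CC(C)N(Cc1cccc(OCCCCCC(=O)O)c1)C(=O)c1ccc(-c2cccc(F)c2)cc1`: > 26000 nM, a limit

In an ADME assay on Raji cells (Homo sapiens) for cytotoxicity, read by CellTiter-Glo and resazurin assay, with a stated time of 72 h (a higher number here means that more compound is needed for the effect, a lower number that less compound is needed), compound 2 gives > 26000 nM. This is a limit and not a number. In this assay, compound 1 gives > 20800 nM, which is also a limit. For the measured compounds named here, compound 2 therefore has no exact value, and neither does the only other compound it can be compared with.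

Compound 3 `CC(C)N(Cc1cccc(OCCCCCC(=O)O)c1)C(=O)c1ccc(-c2ccc(Cl)c(Cl)c2)cc1` has not yet been measured. It carries 3,4-dichlorophenyl in place of 3-fluorophenyl on an aromatic carbon, para to a large group: 3,4-dichlorophenyl in place of 3-fluorophenyl on an aromatic carbon.

Going by the values given here, only one measured step bears on this change, the swap of ethoxy for fluoro on an aromatic carbon: a step that the two limits leave unreadable from compound 1 to compound 2. That step offers no size to carry over, but it does show two different groups that both ended in a limit. No step beyond the scatter is therefore expected in this assay, and compound 3 will probably be reported as a limit too. The expected change is an at least 1.0-fold lower number from compound 2 to compound 3 (0.01 log units; that floor lies within the scatter). The estimate for compound 3 is 25000 nM, with an expected range of 10000 nM to 50000 nM.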

Compound 3, half-maximal effective concentration: > 26000 nM
Compound 3 was reported as a limit (the forecaster's own chance of this, stated with the estimate: 75%); middle value at least 1.0-fold (0.01 log units) away from the limit.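

In this assay compound 3 gives > 26000 nM, which is a limit and not a number. For the compounds shown here, with compound 1, compound 2 and compound 3 all reported as limits, no step among them can be read. The compounds shown leave open how much of each is actually needed for the effect, and whether these group changes alter that amount.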